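A few compounds are considered here, and "the series" means these few. Any claim that something is new, unique, unknown or untested is made for them only; others in the source may bear on it.

Compound 1 `Nc1nc(NCc2cccs2)nc2sc(-c3ccco3)nc12`: 12.5 nM
Compound 2 `COc1cccc(CNc2nc(N)c3nc(-c4ccc(C)o4)sc3n2)c1`: 70 nM
Compound 3 `Nc1nc(NCc2ccncc2)nc2sc(-c3ccco3)nc12`: 47 nM

Of the compounds shown here, three sharing one core have been tested in an assay on CHO cells for displacement of a labelled ligand from adenosine receptor A1 (Homo sapiens), read by scintillation counting, with a stated time of 90 min; a lower number here means a stronger inhibitor, a higher number a weaker inhibitor. Compound 3 gives 47 nM, the second highest of the three numbers; compound 2 sits within the scatter of it at 70 nM, while compound 1 gives 12.5 nM. Compound 4 `Nc1nc(NCc2ccco2)nc2sc(-c3ccco3)nc12` differs from compound 3 in one place: furan-2-yl in place of pyridin-4-yl on a saturated chain carbon bound to a nitrogen on an aromatic ring. Among the compounds with values here, the only measured step at this place is a 3.8-fold higher number from compound 1 to compound 3 (0.58 log units; beyond the scatter), which went from thiophen-2-yl to pyridin-4-yl. Compound 4 moves away from pyridin-4-yl again, so a modest step back toward the number of compound 1 is expected, a 2.4-fold lower number from compound 3 to compound 4 (0.37 log units; beyond the scatter), and compound 4 is estimated at 20 nM, between 8 nM and 60 nM.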

Compound 4, inhibition constant: 38 nM
Compound 4: the middle estimate sits 1.9-fold (0.28 log units) below what was measured; measured number inside the range.
By their numbers in this assay, from the lowest: compound 1; then compounds 4, 3 and 2 (each within the scatter of the next).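

In this assay, furan-2-yl in place of pyridin-4-yl gives a 1.2-fold lower number from compound 3 to compound 4 (0.09 log units; within the scatter), so this change on the saturated chain carbon leaves the number within the scatter. Furan-2-yl in place of thiophen-2-yl gives a 3.0-fold higher number from compound 1 to compound 4 (0.48 log units; beyond the scatter), so here the gain seen with thiophen-2-yl is not shared by furan-2-yl, even though both are five-membered aromatic rings. No evidence is available to explain this difference.

From the compounds shown here alone, whether a plain phenyl ring or a saturated piperidine ring at this place would match thiophen-2-yl remains open.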